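Purine amide benzyl esters: side-chain swap at the amino acid

The source may hold more compounds than are shown below. What is called first, only, known or untested is meant among the compounds shown, and "the series" means these compounds.

In a functional assay on the whole organism (Tail, strain ICR) with Mus musculus as the target, in the tail flick test, with a stated time of 30 min, at a dose of 25 umol/kg by the oral route (a lower number here means a weaker effect, a higher number a stronger effect of the compound at the dose given), compound 1 `CSCC[C@H](NC(=O)CN(c1nc(Cl)nc2[nH]cnc12)C1CC1)C(=O)OCc1ccccc1` gives 22.2%, the lowest of the two numbers recorded. Its nearest neighbour is compound 2 `O=C(OCc1ccccc1)[C@@H]1CCCN1C(=O)CN(c1nc(Cl)nc2[nH]cnc12)C1CC1`, which in this assay gives 33.2%, a gap that lies beyond the usual scatter. Going by the values given here, no single-point step has been measured in this set, so the effect of a side-chain exchange at the amino acid position is not known from direct pairs.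

Compound 3 `CC(C)C[C@H](NC(=O)CN(c1nc(Cl)nc2[nH]cnc12)C1CC1)C(=O)OCc1ccccc1` is the next compound, not yet measured. It differs from compound 1 by isopropyl in place of (methylsulfanyl)methyl on a saturated chain carbon, two bonds along the chain from an amide-type nitrogen and a carbonyl carbon. Among the compounds with values here, with no measured step of this type to draw on, the step expected for compound 3 is small and in no settled direction, and is estimated to lie within the scatter as a number 2.8 percentage points higher from compound 1 to compound 3 (within the scatter). For compound 3 in this assay the expected value is 25%, with a range from 10% to 45%.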

Compound 3, a percentage reported as activity, at one dose (the size of the read-out at that dose, not a potency): 33.9%
Estimate against measurement, compound 3: 8.9 percentage points below; the range from low to high includes it.
By their numbers in this assay, from the lowest: compound 1; then compounds 2 and 3 (each within the scatter of the next).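

In this assay this position now has its first direct step: isopropyl in place of (methylsulfanyl)methyl, on a saturated chain carbon, two bonds along the chain from an amide-type nitrogen and a carbonyl carbon, gives a number 11.7 percentage points higher from compound 1 to compound 3 (beyond the scatter) and so shows that the read-out at this dose responds to the side chain here. The exchange leaves the count of 3 heavy atoms unchanged, while the sulfur and the 1 hydrogen-bond acceptor counted for the leaving group are gone. No measurement at hand accounts for the step.

As far as these compounds go, whether the loss of sulfur or the branching goes with the step remains open, and a straight all-carbon chain such as n-propyl at this carbon would separate the two. Also open, from the compounds shown here alone, is how an amine on the side chain or a carboxylic acid in place of the benzyl ester would read.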